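The compounds below may be only part of what the source reports. "The series", "measured", "known", "first", "only" and "open" are said of these compounds alone.

Compounds measured so far: compound 1 `Cc1cc(NC(=O)Cn2nnc(-c3ccccc3)n2)n(C2CCC(F)(F)CC2)n1` gives 84 nM in an assay on HEK293 cells for activation of Kir3.1/Kir3.2 (Homo sapiens), read by thallium flux; on this read-out higher numbers stand for an effect only at larger amounts of compound and lower numbers for an effect already at smaller amounts. Compound 3 `O=C(Cn1nnc(-c2ccccc2)n1)Nc1cc(C2CC2)nn1C1CCCCC1` gives 271 nM. Compound 2 `CC1(c2cc(NC(=O)Cn3nnc(-c4ccccc4)n3)n(C3CCCCC3)n2)CC1` gives only > 10000 nM, which is a limit of this assay (the limit of > 10000 nM in this assay, at which 1 of the 3 values shown sits).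

Among the two numbers, compound 1 has the lowest, with compound 3 next and beyond the scatter. For the measured compounds named here, the one measured step is an at least 36-fold lower number from compound 2 to compound 3 (1.56 log units; beyond the scatter), and it concerns a saturated ring, not the aromatic nitrogen.

Compound 4 `Cc1cc(NC(=O)Cn2nnc(-c3ccccc3)n2)n(-c2ccccc2)n1` differs from compound 1 by phenyl in place of 4,4-difluorocyclohexyl on an aromatic nitrogen. Going by the values given here, no measured step covers a change on the aromatic nitrogen, so the direction is open. Compound 4 is therefore estimated at 300 nM, between 60 nM and 2500 nM, an expected step of a 3.6-fold higher number from compound 1 to compound 4 (0.55 log units; beyond the scatter).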

Compound 4, half-maximal effective concentration: 3020 nM
For compound 4 the middle estimate is 10-fold (1.00 log units) below the measured one; the measured number lies above the stated range.
By their numbers in this assay, from the lowest: compound 1; then compound 3; then compound 4. At a limit, above all of these: compound 2.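

On the aromatic nitrogen the group matters strongly: phenyl in place of 4,4-difluorocyclohexyl gives a 36-fold higher number from compound 1 to compound 4 (1.56 log units; beyond the scatter), a large step. This settles the direction at this position, with the saturated ring giving the lower number on this core. Nothing measured here accounts for the size of the step.

The change removes the fluorine and the saturated ring together, and the compounds shown do not separate the two. From the compounds shown here alone, how a tetrahydropyranyl ring or an isopropyl group on this nitrogen would read also stays open.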